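The source may report more compounds than this note shows. Statements on the series, on what has been measured and on what is new or still open speak of the compounds shown alone.

Compound 1 `CC(=O)C1(c2cc(F)cc(OCc3ccc(-n4ccnc4C)cc3)c2)CCOCC1` carries an acetyl group on the saturated ring carbon of its oxygen-containing ring; in an assay on blood for inhibition of Polyunsaturated fatty acid 5-lipoxygenase (Homo sapiens) (a higher number here means a weaker inhibitor, a lower number a stronger inhibitor), compound 1 gives 130 nM. Compound 2 `COC1(c2cc(F)cc(OCc3ccc(-n4ccnc4C)cc3)c2)CCOCC1` has a methoxy group at that carbon instead, and in this assay compound 2 gives 60 nM. Among the compounds with values here, the single step seen so far, a 2.2-fold lower number from compound 1 to compound 2 (0.34 log units; beyond the scatter), is modest but beyond the scatter, and it leaves compound 2 with the lowest of the two numbers recorded, compound 1 standing above it.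

Compound 3 `CCOC(=O)C1(c2cc(F)cc(OCc3ccc(-n4ccnc4C)cc3)c2)CCOCC1` alters the same carbon again: ethoxycarbonyl in place of methoxy on a saturated ring carbon. Within the data shown here, only the step from compound 1 to compound 2 bears on this, since it is the only change made at that position, and it was modest in size. Among the measured compounds shown here, no measured compound carries an ethoxycarbonyl group, so the direction of the new step rests on little. As compound 1, which carries a carbonyl at this carbon, gave 130 nM, a return toward that level is expected, so the step of a 1.8-fold higher number from compound 2 to compound 3 (0.26 log units; within the scatter) is estimated as a modest rise, possibly within the scatter. For compound 3 the expected value in this assay is 110 nM, with a range from 45 nM to 280 nM.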

Compound 3, half-maximal inhibitory concentration: 200 nM
For compound 3 the middle estimate is 1.8-fold (0.26 log units) below the measured one; measured number inside the range.
By their numbers in this assay, from the lowest: compound 2; then compounds 1 and 3 (each within the scatter of the next).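

In this assay the change from methoxy to ethoxycarbonyl on the saturated ring carbon gives a 3.3-fold higher number from compound 2 to compound 3 (0.52 log units; beyond the scatter) and so sets a second carbonyl-bearing group apart from the methoxy group, with compound 2 now beyond the scatter of both other compounds and the strongest inhibitor of the three. Ethoxy in place of methyl on the carbonyl carbon gives a 1.5-fold higher number from compound 1 to compound 3 (0.19 log units; within the scatter) and stays within the scatter, so compound 1 and compound 3 cannot be told apart, and the larger ethoxycarbonyl group is not separated from the acetyl group at this position. Nothing at hand explains why the two carbonyl-bearing compounds stand together on the higher side of compound 2.

The three compounds leave open whether the lower number belongs to methoxy alone or would hold for an ether with a longer chain, such as ethoxy. They also leave open how a hydroxyl group, an amine or a carboxylic acid on this saturated ring carbon would read in this assay on the same core.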